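This account rests on a few compounds, and the source may have more. Where it says the series, first, only, none or still open, it means among the compounds named here.

Measured compounds in a functional assay on U-937 cells (Homo sapiens) for cytotoxicity, read by CCK-8 assay, with a stated time of 72 h; on this read-out higher numbers stand for weaker inhibition and lower numbers for stronger inhibition:
- compound 1 `C=CCn1c(=O)/c(=C\c2cccc(F)c2)[nH]c(=O)/c1=C\c1ccccc1OC` — 2500 nM
- compound 2 `COc1ccccc1/C=c1\c(=O)[nH]/c(=C/c2ccccc2Cl)c(=O)n1C` — 100 nM
- compound 3 `C=CCn1c(=O)/c(=C\c2cccc(Br)c2)[nH]c(=O)/c1=C\c1cccc(Br)c1` — "not active" (no number reported)

Among the two compounds with a number in this assay, compound 1 stands highest. Compound 2 gives a much lower number, and the gap between compound 1 and compound 2 lies well beyond the usual scatter, though the two compounds differ in more than one place and no single step accounts for it. Compound 3 has no number at all and is simply described as not active.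

Compound 4 `C=CCn1c(=O)/c(=C\c2ccc(C)cc2)[nH]c(=O)/c1=C\c1ccccc1OC` is still to be measured. It differs from compound 1 in one place: 4-methylphenyl in place of 3-fluorophenyl on a double-bonded chain carbon bound to an aromatic carbon. Within the data shown here, no pair of measured compounds shows this same change, so there is no measured step to lean on. Compound 3, which carries a halogen on both aryl groups, shows no activity, while compound 1 with a single 3-fluorophenyl keeps a measurable number. On this basis the expected step from compound 1 to compound 4 is small, either none beyond the scatter or a modest move toward a higher number, giving a 1.6-fold higher number from compound 1 to compound 4 (0.20 log units; within the scatter).

Compound 4 is therefore estimated to give about 4000 nM in this assay, with a plausible range from 1200 nM to 15000 nM.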

Compound 4, half-maximal inhibitory concentration: "not active" (no number reported)
No number was reported for compound 4; the estimate stays without a comparison.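

In this assay compound 4 gives "not active" (no number reported) and carries no number, so no step can be read between compound 1 and compound 4. The compounds shown leave open how far 4-methylphenyl in place of 3-fluorophenyl moves the number on this read-out. No measured evidence bears on this result.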